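Aryl Exchange on the Ring Amine Nitrogen of Compound 2

The source may hold more compounds than are shown below. What is called first, only, known or untested is meant among the compounds shown, and "the series" means these compounds.

Compound 2 `Nc1scc(CN2CCN(c3ccc(Cl)cc3Cl)CC2)c1C(=O)c1ccc(Cl)cc1` was tested in a functional assay on CHO cells with adenosine receptor A1 (Homo sapiens) as the target, read by cAMP accumulation and immunoassay, with a stated time of 6 min, tested at 0.01 uM (a higher number here means a weaker effect of the compound at the concentration tested, a lower number a stronger effect), and gave 2%. Among the three measured numbers it stands second highest: its nearest neighbour is compound 1 `CC(C)N1CCN(Cc2csc(N)c2C(=O)c2ccc(Cl)cc2)CC1`, which gives -1%, the step being a number 3 percentage points higher from compound 1 to compound 2 (within the scatter); the furthest is compound 3 `Nc1scc(CN2CCN(c3ccc(F)cc3Cl)CC2)c1C(=O)c1ccc(Cl)cc1`, which gives 6.1%, the step being a number 4.1 percentage points higher from compound 2 to compound 3 (within the scatter). Compound 4 `Nc1scc(CN2CCN(c3ccccc3C(F)(F)F)CC2)c1C(=O)c1ccc(Cl)cc1` differs from compound 2 in one place: 2-(trifluoromethyl)phenyl in place of 2,4-dichlorophenyl on an amine nitrogen in a ring. Among the compounds with values here, the steps that bear on this change are those where an aryl group replaced isopropyl on the ring amine nitrogen, a number 3 percentage points higher from compound 1 to compound 2 (within the scatter) and a number 7.1 percentage points higher from compound 1 to compound 3 (within the scatter), and the halogen exchange within such an aryl group, a number 4.1 percentage points higher from compound 2 to compound 3 (within the scatter). All three lie within the scatter, and every measured compound sits near zero. The expected step is therefore no change at the digits printed from compound 2 to compound 4 (within the scatter), none beyond the scatter. Compound 4 is thus estimated at 2%, with a range from -8% to 12%.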

Compound 4, a percentage reported as activity, at one concentration (the size of the read-out at that concentration, not a potency): 0%
Compound 4: the middle estimate sits 2 percentage points above what was measured; measured number inside the range.
By their numbers in this assay, from the lowest: compounds 1, 4, 2 and 3 (each within the scatter of the next).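

In this assay, 2-(trifluoromethyl)phenyl on the ring amine nitrogen gives a number 2 percentage points lower from compound 2 to compound 4 (within the scatter) and a number 6.1 percentage points lower from compound 3 to compound 4 (within the scatter) when it replaces the two halogen-bearing aryl groups, and a number 1 percentage points higher from compound 1 to compound 4 (within the scatter) when it replaces isopropyl. The earlier compounds shown here covered only chloro and fluoro on the aryl ring and isopropyl, so this result adds a trifluoromethyl-bearing aryl group, with 10 heavy atoms in place of 8, and still no step at this position leaves the scatter. No supporting measurement is available to explain why these numbers stay together.

Going by these compounds, whether a carboxylic acid, a primary amine or a longer alkyl chain on this nitrogen would move the number beyond the scatter remains open. The read-out also comes from one concentration, so any differences in potency among these compounds remain unresolved.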